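Cytotoxicity notes: one methyl step across two cores

A few compounds are considered here, and "the series" means these few. Any claim that something is new, unique, unknown or untested is made for them only; others in the source may bear on it.

Compound 1 `CN(CC(=O)O)Cc1c(O)ccc2ccc(=O)oc12` gives in an ADME assay on MT4 cells (Homo sapiens) for cytotoxicity, read by MTT assay, with a stated time of 96 h (a higher number here means that more compound is tolerated, a lower number that less compound is tolerated), a limit only, > 100000 nM.
Compound 2 `O=C(Oc1ccc2ccc(=O)oc2c1CN1CCc2ccccc2C1)c1ccccc1` gives in this assay a limit only, > 100000 nM.
Compound 3 `Cc1cc(=O)oc2c(CN3CCc4ccccc4C3)c(OC(=O)c3ccccc3)ccc12` gives in this assay a limit only, > 100000 nM.

Every value in hand is a limit of this assay: the limit of > 100000 nM in this assay, at which 3 of the 3 values shown sit. Among the measured compounds shown here, the one change made between measured compounds, (methyl in place of hydrogen on an aromatic carbon), gives the step that the two limits leave unreadable from compound 2 to compound 3. How the core of compound 1 differs from the core of compound 2 is not broken down here.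

Compound 4 `Cc1cc(=O)oc2c(CN(C)CC(=O)O)c(O)ccc12` is not yet measured in this assay. It differs from compound 1 by methyl in place of hydrogen on an aromatic carbon, the same change as from compound 2 to compound 3, at a place described in the same words. The step is expected to be a number no higher from compound 1 to compound 4 (the limit leaves the size open), because the measured step that the two limits leave unreadable from compound 2 to compound 3 is unreadable and because all three values sit at the limit (the limit of > 100000 nM in this assay, at which 3 of the 3 values shown sit). Compound 4 is therefore estimated at 100000 nM, most likely reported as a limit again, with a range from 40000 nM to 300000 nM.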

Compound 4, half-maximal cytotoxic concentration: > 100000 nM
Compound 4: a limit, no number; the forecaster's own chance of this, stated with the estimate: 80%; the middle value sits exactly at the limit.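

No step can be read from compound 1 to compound 4, because both results in this assay are limits: the limit of > 100000 nM in this assay, at which 4 of the 4 values shown sit. The compounds shown leave open whether methyl in place of hydrogen on an aromatic carbon alters cytotoxicity on either core, and at what concentration any of the four compounds becomes cytotoxic.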